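The source may hold more compounds than are shown below. What is called first, only, known or untested is meant among the compounds shown, and "the series" means these compounds.

Measured so far in an assay on liver (Sus scrofa) for inhibition of glucose-6-phosphatase catalytic subunit 1 (Homo sapiens), using microsomes; on this read-out higher numbers stand for weaker inhibition and lower numbers for stronger inhibition:

compound 1, `COc1ccc(/C=N/N(Cc2ccccc2)Cc2ccccc2)cc1`: 220 nM
compound 2, `CCc1ccc(/C=N/N(Cc2ccccc2)Cc2ccccc2)o1`: 330 nM
compound 3, `Clc1ccc(/C=N/N(Cc2ccccc2)Cc2ccccc2)s1`: 170 nM

Compound 1 holds the second highest of these three numbers, but neither neighbour is separated from it beyond the usual scatter: the step of a 1.3-fold lower number from compound 1 to compound 3 (0.11 log units; within the scatter) is the nearest, and the step of a 1.5-fold higher number from compound 1 to compound 2 (0.18 log units; within the scatter) the furthest. The remaining pair, a 1.9-fold lower number from compound 2 to compound 3 (0.29 log units; within the scatter), also stays within the scatter. All three measured compounds share one core and differ only in the ring on the carbon with a double bond to nitrogen.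

Compound 4, `O=[N+]([O-])c1ccc(/C=N/N(Cc2ccccc2)Cc2ccccc2)o1`, has not yet been measured in this assay. Relative to compound 1 the change is 5-nitrofuran-2-yl in place of 4-methoxyphenyl on a carbon with a double bond to nitrogen. Among the measured compounds shown here, two measured steps bear on it, both exchanging the 4-methoxyphenyl of compound 1 for a five-membered heteroaryl ring: a 1.5-fold higher number from compound 1 to compound 2 (0.18 log units; within the scatter) and a 1.3-fold lower number from compound 1 to compound 3 (0.11 log units; within the scatter), each within the scatter. For the measured compounds named here, no measured compound carries a nitro group, so the nitrofuran has no precedent here. On that basis compound 4 is expected to stay within the scatter of compound 1, with the step of a 1.1-fold higher number from compound 1 to compound 4 (0.06 log units; within the scatter) as the estimate. The value expected for compound 4 in this assay is 250 nM, with a range from 100 nM to 650 nM.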

Compound 4, half-maximal inhibitory concentration: > 100000 nM
Compound 4: a limit, no number; the forecaster's own chance of this, stated with the estimate: 5%; middle value at least 400-fold (2.60 log units) from the limit.
By their numbers in this assay, from the lowest: compounds 3, 1 and 2 (each within the scatter of the next). At a limit, above all of these: compound 4.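

In this assay compound 4 stands at a limit of the assay, not at a number: the limit of > 100000 nM in this assay, at which 1 of the 4 values shown sits.

The earlier exchanges on the carbon with a double bond to nitrogen all stayed within the scatter, whereas 5-nitrofuran-2-yl at this place gives an at least 450-fold higher number from compound 1 to compound 4 (2.65 log units; beyond the scatter) and an at least 580-fold higher number from compound 3 to compound 4 (2.76 log units; beyond the scatter), so this position does not accept every five-membered aromatic ring alike. With the furan ring kept and only nitro in place of ethyl on an aromatic carbon, the step is an at least 300-fold higher number from compound 2 to compound 4 (2.48 log units; beyond the scatter), so a furan ring alone does not bring the read-out to this limit.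

As far as these compounds go, whether a nitrile or a carboxylic acid in place of the nitro on the furan ring would reach the same limit remains open. The compounds shown also leave open whether a nitro group on the phenyl ring of compound 1 would do the same.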